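The compounds below may be only part of what the source reports. "The series", "measured", "known", "first", "only" and "open" are said of these compounds alone.

Measured compounds in a functional assay (B cells) with Mus musculus as the target; a lower number here means that less compound is needed, a higher number that more compound is needed for the effect:
- compound 1 `Nc1nc(O)c2c(n1)n(C1OC(CO)[C@@H](O)[C@H]1O)c(=O)n2CC(O)CO` gives 45 uM
- compound 2 `C=CCn1c(=O)n(CCCCCCCC)c2nc(N)nc(O)c21` gives 37 uM
- compound 3 `C=CCn1c(=O)n([C@@H]2O[C@H](CO)[C@H]3OC(CCC)(CCC)O[C@H]32)c2nc(N)nc(O)c21` gives 4 uM

Compound 1 has the highest number of the three in this assay. Compound 2 sits within the scatter of it, so no order can be read between the two. Compound 3 lies beyond the scatter with a lower number.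

Compound 4 `Nc1nc(O)c2c(n1)n(C1OC(CO)[C@@H](O)[C@H]1O)c(=O)n2Cc1ccc(Cl)cc1` differs from compound 1 by 4-chlorophenyl in place of 1,2-dihydroxyethyl on a saturated chain carbon bound to an aromatic nitrogen. For the measured compounds named here, no measured pair isolates this change, so the expectation rests on the spread of the three values alone, with compound 3 showing that lower numbers are reachable in this core. A step downward beyond the scatter is expected, about a 3.8-fold lower number from compound 1 to compound 4 (0.57 log units; beyond the scatter). Compound 4 is estimated at 12 uM, with a range from 3 uM to 45 uM.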

Compound 4, concentration for half-maximal effect: 14 uM
Estimate against measurement, compound 4: 1.2-fold (0.07 log units) below, and the stated range covers the measured number.
By their numbers in this assay, from the lowest: compound 3; then compound 4; then compounds 2 and 1 (each within the scatter of the next).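

In this assay, for the compounds shown here, this place, a saturated chain carbon bound to an aromatic nitrogen, is the first to be read in isolation: 4-chlorophenyl in place of 1,2-dihydroxyethyl gives a 3.2-fold lower number from compound 1 to compound 4 (0.51 log units; beyond the scatter). The group here therefore changes the number on the shared core, although the step is modest. No measurement on hand accounts for the step.

On these data alone, whether the aromatic ring, the chlorine or the loss of the hydroxyl groups carries the step stays open. An unsubstituted benzyl, an amine or a carboxylic acid at this place would help separate these.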